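Indane in Place of Indole on the Ether Oxygen

The source may report more compounds than this note shows. Statements on the series, on what has been measured and on what is new or still open speak of the compounds shown alone.

Of the compounds shown here, three sharing one core have been measured in an assay on microsomes from liver for inhibition of acyl-CoA desaturase 1 (Rattus norvegicus); a higher number here means a weaker inhibitor, a lower number a stronger inhibitor. Compound 1 `Cc1cccc(OC2CCN(c3ccc(-n4ccnc4)nn3)CC2)c1` gives 251 nM. Compound 2 `c1cc(OC2CCN(c3ccc(-n4ccnc4)nn3)CC2)c2cc[nH]c2c1` gives 162 nM, and compound 3 `FC(F)(F)c1cccc(OC2CCN(c3ccc(-n4ccnc4)nn3)CC2)c1` gives 19 nM. Compound 2 stands second highest of these three numbers: its nearest neighbour is compound 1, with the step of a 1.5-fold lower number from compound 1 to compound 2 (0.19 log units; within the scatter) lying within the scatter, while the step of a 13-fold lower number from compound 1 to compound 3 (1.12 log units; beyond the scatter) is large and sets compound 3 well apart from both.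

The untested compound 4 `c1cc2c(c(OC3CCN(c4ccc(-n5ccnc5)nn4)CC3)c1)CCC2` differs from compound 2 at the oxygen on the saturated carbon: 2,3-dihydro-1H-inden-4-yl in place of 1H-indol-4-yl on an oxygen on a saturated carbon. Among the compounds with values here, no measured step tests this exact exchange. Within the data shown here, the only step that touches the same place, a 1.5-fold lower number from compound 1 to compound 2 (0.19 log units; within the scatter), stayed within the scatter, whereas the large gain seen in compound 3 came from trifluoromethyl on an aromatic carbon, a change compound 4 does not contain. The step of a 1.1-fold lower number from compound 2 to compound 4 (0.03 log units; within the scatter) is therefore expected to stay within the scatter. The value expected for compound 4 in this assay is 150 nM, within a range from 60 nM to 400 nM.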

Compound 4, half-maximal inhibitory concentration: 10 nM
The estimate for compound 4 lay 15-fold (1.18 log units) above the measured number; measured number below the stated range.
By their numbers in this assay, from the lowest: compounds 4 and 3 (each within the scatter of the next); then compounds 2 and 1 (each within the scatter of the next).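

In this assay this position on an oxygen on a saturated carbon proves highly responsive: a 16-fold lower number from compound 2 to compound 4 (1.21 log units; beyond the scatter) is large, although 2,3-dihydro-1H-inden-4-yl has the same heavy-atom count as 1H-indol-4-yl and loses its nitrogen and hydrogen-bond donor. With a 25-fold lower number from compound 1 to compound 4 (1.40 log units; beyond the scatter) also large, a change at this position alone is enough for a large gain, which earlier appeared only with trifluoromethyl on an aromatic carbon, while the step from 3-methylphenyl to 1H-indol-4-yl had stayed within the scatter. Nothing available explains why the number falls so far.

The compounds shown do not separate the loss of the nitrogen from the change to a non-aromatic five-membered ring. They also leave open how an amine, a carboxylic acid or a longer alkyl chain on 2,3-dihydro-1H-inden-4-yl would fare.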